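A six-membered ring on the oxygen of compound 4

The source may hold more compounds than are shown below. What is called first, only, known or untested is meant among the compounds shown, and "the series" means these compounds.

Among the compounds with values here, in a functional assay on NCI-H460 cells (Homo sapiens) for cytotoxicity, read by MTT assay, with a stated time of 96 h (on this read-out higher numbers stand for weaker inhibition and lower numbers for stronger inhibition), three compounds have numbers so far. Compound 1 `COc1ncc(-c2cc(OC3CCOCC3)c3nc(N)nc(C)c3c2)cc1NS(C)(=O)=O` gives 860 nM, the highest of them, and compound 2 `CNc1nc(C)c2cc(-c3cnc(OC)c(NS(=O)(=O)c4ccc(F)cc4F)c3)cc(OC3CCOCC3)c2n1` gives 59 nM, the lowest. Compound 3 `CNc1nc(C)c2cc(-c3cnc(OC)c(NS(=O)(=O)c4ccc(F)cc4F)c3)cc(OCC3CCOC3)c2n1` gives 310 nM, which places it in the middle of the three and nearer to compound 1 than to compound 2.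

Compound 4 `CNc1nc(C)c2cc(-c3cnc(OC)c(NS(=O)(=O)c4ccc(F)cc4F)c3)cc(OC3CCOC(C)(C)C3)c2n1` has not yet been measured. It differs from compound 3 on an oxygen on an aromatic ring, where 2,2-dimethyloxan-4-yl stands in place of (oxolan-3-yl)methyl: 2,2-dimethyloxan-4-yl in place of (oxolan-3-yl)methyl on an oxygen on an aromatic ring. Within the data shown here, one measured step bears directly on this change: a 5.3-fold higher number from compound 2 to compound 3 (0.72 log units; beyond the scatter). That modest step, beyond the scatter, put (oxolan-3-yl)methyl in place of oxan-4-yl. Among the measured compounds shown here, the change to compound 4 runs the other way and restores a six-membered non-aromatic ring, but that ring also carries the dimethyl pair, and no measured compound shows what this pair does. Only part of the step seen with compound 2 and compound 3 is therefore expected to be reversed. The expected move is toward a lower number, and the estimated size is a 3.1-fold lower number from compound 3 to compound 4 (0.49 log units; beyond the scatter). The estimate for compound 4 is 100 nM, with an expected range from 35 nM to 290 nM.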

Compound 4, half-maximal inhibitory concentration: 250 nM
Beside the measured number, compound 4's estimate is 2.5-fold (0.40 log units) below it, and the stated range covers the measured number.
By their numbers in this assay, from the lowest: compound 2; then compounds 4 and 3 (each within the scatter of the next); then compound 1.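

In this assay, putting a six-membered non-aromatic ring back on the oxygen did not by itself return the number to that of compound 2: 2,2-dimethyloxan-4-yl in place of (oxolan-3-yl)methyl gives a 1.2-fold lower number from compound 3 to compound 4 (0.09 log units; within the scatter) and so cannot be told apart from the five-membered group at this position. Within the data shown here, the comparison with oxan-4-yl isolates the dimethyl pair, which no earlier pair of compounds could do, and 2,2-dimethyloxan-4-yl in place of oxan-4-yl gives a 4.2-fold higher number from compound 2 to compound 4 (0.63 log units; beyond the scatter) as a step beyond the scatter. Among these three compounds, ring size alone therefore does not follow the numbers, since compound 4 carries a six-membered ring like compound 2 yet lies within the scatter of compound 3, which carries a five-membered ring.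

As far as these compounds go, it remains open whether a single methyl group on the oxan-4-yl ring would stay close to compound 2 or to compound 4, and whether a piperidin-4-yl group, with an amine in place of the ring oxygen, would be tolerated on this oxygen. Nothing available here accounts for the size of these steps.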